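This account rests on a few compounds, and the source may have more. Where it says the series, first, only, none or still open, it means among the compounds named here.

Working notes on the series, read in an ADME assay on HT-29 cells (Homo sapiens) for cytotoxicity, read by MTT assay, with a stated time of 72 h; a higher number here means a weaker inhibitor, a lower number a stronger inhibitor. Within the data shown here, compound 1 `COc1ccc(OC)c(C2=C(c3cc(OC)c(OC)c(OC)c3)C(=O)CC2O[SiH2]C(C)(C)C)c1` gives 5 ug/mL, the only true number so far. For compound 2 `COc1cc(C2=C(c3ccc(OCC(=O)O)cc3)C(O)CC2=O)cc(OC)c1OC` the entry reads "not determined" (no result reported). Compound 3 `COc1ccc(OC)c(C2=C(c3cc(OC)c(OC)c(OC)c3)C(=O)CC2O)c1` gives > 100 ug/mL, which is a limit of the assay and not a number.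

Among the measured compounds shown here, only one measured step exists: replacing the silicon-bearing group of compound 1 with hydrogen gives an at least 20-fold higher number from compound 1 to compound 3 (1.30 log units; beyond the scatter). Its size is open-ended since it rests on (the limit of > 100 ug/mL in this assay, at which 1 of the 3 values shown sits).

Next in line is compound 4 `COc1cc(C2=C(c3cc(C)c(OC)c(C)c3)C(O[SiH2]C(C)(C)C)CC2=O)cc(OC)c1OC`. The change is 4-methoxy-3,5-dimethylphenyl in place of 2,5-dimethoxyphenyl on a double-bonded ring carbon. Compound 4 keeps the silicon-bearing group, so the change lies elsewhere than the measured step of an at least 20-fold higher number from compound 1 to compound 3 (1.30 log units; beyond the scatter), and that step gives no size for this exchange. For the measured compounds named here, no measured pair covers an exchange at this place. The expectation therefore stays anchored on compound 1 at 5 ug/mL, with a wide margin.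

The expected outcome is no change at the digits printed from compound 1 to compound 4 (within the scatter), which means no expected shift beyond the scatter in either direction.

For compound 4 the estimated value is 5 ug/mL, with an expected range from 1.5 ug/mL to 20 ug/mL.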

Compound 4, half-maximal inhibitory concentration: 10 ug/mL
For compound 4 the middle estimate is 2.0-fold (0.30 log units) below the measured one, and the stated range covers the measured number.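

In this assay, among these compounds, 4-methoxy-3,5-dimethylphenyl in place of 2,5-dimethoxyphenyl on a double-bonded ring carbon gives a 2.0-fold higher number from compound 1 to compound 4 (0.30 log units; within the scatter), the first reading of any exchange at this place. With the silicon-bearing group kept, this aryl exchange does not move the reading beyond the scatter, and it stands apart from the one earlier step, at the oxygen on a saturated carbon, which gave an at least 20-fold higher number from compound 1 to compound 3 (1.30 log units; beyond the scatter), so among the compounds shown only the loss of the silicon-bearing group has a size beyond the scatter. Nothing measured here speaks to a cause for this reading at the aryl position.

Open is whether 4-methoxy-3,5-dimethylphenyl would read the same way with hydrogen in place of the silicon-bearing group, a pair that the compounds shown do not supply. Also open, going by these compounds, is how far this place tolerates other groups, such as an aryl group carrying an amine or a nitrile, since the two aryl groups compared here carry only methoxy and methyl groups.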